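Replacing Benzyl with 4-Propylphenyl on Two Related Cores

The source may report more compounds than this note shows. Statements on the series, on what has been measured and on what is new or still open speak of the compounds shown alone.

Four compounds share a core that carries an amine on a double-bonded ring carbon, and they differ in the group on that amine and in how the core is put together. Compound 2 `O=C1C=C(NCc2ccccc2)C(=O)c2c1nc1n2[C@H]2OC[C@@H](O)[C@H]2OC1` carries benzyl on the amine. Compound 1 `CCCc1ccc(NC2=CC(=O)c3nc4n(c3C2=O)[C@H]2OC[C@@H](O)[C@H]2OC4)cc1` differs from it by 4-propylphenyl in place of benzyl on an amine nitrogen. Compound 3 `O=C1C(NCc2ccccc2)=CC(=O)c2c1nc1n2[C@H]2OC[C@@H](O)[C@H]2OC1` is built from the same atoms as compound 2, joined differently; the difference between the two cores is not broken down here. Compound 4 `CCCc1ccc(NC2=CC(=O)c3c(nc4n3[C@H]3OC[C@@H](O)[C@H]3OC4)C2=O)cc1` has not been measured; it differs from compound 3 by 4-propylphenyl in place of benzyl on an amine nitrogen, the same change as that from compound 2 to compound 1, made at the same place on the amine.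

In a functional assay on ECa-109 cells for inhibition, with ECa-109 cell line (Homo sapiens) as the target, read by sulforhodamine B assay (a lower number here means a stronger inhibitor, a higher number a weaker inhibitor), compound 2 reaches only a limit, > 8000 nM. Compound 3 likewise gives only a limit, > 8000 nM. Compound 1 also stops at a limit, > 4000 nM. The step that the two limits leave unreadable from compound 2 to compound 1 therefore cannot be sized, since compound 2 sits at the limit of > 8000 nM in this assay, at which 2 of the 3 values shown sit. Compound 1 sits at the limit of > 4000 nM in this assay, at which 1 of the 3 values shown sits. Neither limit shows whether the exchange helped or hurt.

For compound 4 the writer expects a step that the limit leaves unreadable from compound 3 to compound 4, no more readable than the earlier one. This rests on compound 1, which with the same group gave only > 4000 nM. Compound 4 is therefore estimated at 9000 nM, between 4000 nM and 25000 nM, most likely reported only as a limit.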

Compound 4, half-maximal inhibitory concentration: > 4000 nM
Compound 4: only a limit was reported; the forecaster's own chance of this, stated with the estimate: 85%; the middle value is on the limit's open side.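

In this assay compound 4 gives only a limit, > 4000 nM. Compound 3 also gives only a limit, > 8000 nM, so the exchange of benzyl for 4-propylphenyl between compound 3 and compound 4 cannot be sized. The compounds shown leave open whether either group gives the stronger inhibitor on either core, and whether the two cores differ at all.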